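The compounds below may be only part of what the source reports. "The series", "measured", "known", "first", "only" and "open" are said of these compounds alone.

Measured compounds in a functional assay on WiDr cells (Homo sapiens) for inhibition, read by sulforhodamine B assay, with a stated time of 48 h; a lower number here means a stronger inhibitor of growth, a higher number a weaker inhibitor of growth:
- compound 1 `COC(=O)[C@@]1(C)CCC=C2[C@@H]1CC[C@@H](C)[C@]2(C)Cc1c[nH]c2ccc(C(F)(F)F)cc12`: compound 1 gives 18000 nM
- compound 2 `COC(=O)[C@@]1(C)CCC=C2[C@@H]1CC[C@@H](C)[C@]2(C)Cc1c(C)[nH]c2ccc(OC)cc12`: compound 2 gives 17000 nM
- compound 3 `COC(=O)[C@@]1(C)CCC=C2[C@@H]1CC[C@@H](C)[C@]2(C)Cc1c(C)n(C(c2ccccc2)c2ccccc2)c2ccc(Cl)cc12`: compound 3 gives > 100000 nM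

Compound 1 and compound 2 sit within the usual scatter of each other in this assay, so no order between them is claimed. Compound 3 is a different case: its value in this assay is a limit of the assay and not a number. Compound 3 therefore stands at the limit of > 100000 nM in this assay, at which 1 of the 3 values shown sits, and no spacing between it and compound 1 or compound 2 can be read off beyond the fact that both of those gave numbers.

Compound 4 `Cc1c(C[C@]2(C)C3=CCC[C@](C)(C(=O)O)[C@H]3CC[C@H]2C)c2cc(Cl)ccc2n1C(c1ccccc1)c1ccccc1` has not been measured. It differs from compound 3 by hydrogen in place of methyl on an oxygen next to a carbonyl group. For the measured compounds named here, no measured pair carries that change, so neither its direction nor its size is fixed by the data. The step from compound 3 to compound 4 is expected to be an at least 1.1-fold lower number from compound 3 to compound 4 (0.04 log units; that floor lies within the scatter), which is to say no real movement, with a good chance that compound 4 again returns only a limit. Compound 4 is estimated at 90000 nM, in the range 20000 nM to 300000 nM.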

Compound 4, concentration for 50% growth inhibition: 16000 nM
For compound 4 the middle estimate is 5.6-fold (0.75 log units) above the measured one, outside the stated range (below it).
By their numbers in this assay, from the lowest: compounds 4, 2 and 1 (each within the scatter of the next). At a limit, above all of these: compound 3.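

In this assay, for the compounds shown here, the change from methoxycarbonyl to carboxy gives the first readable single change: an at least 6.2-fold lower number from compound 3 to compound 4 (0.79 log units; beyond the scatter). This position on the shared core therefore responds to the change, and hydrogen in place of methyl on the oxygen moves this substitution pattern from a limit of the assay to a measured number. The true size of the step stays unknown because the value for compound 3 is a limit and not a number: the limit of > 100000 nM in this assay, at which 1 of the 4 values shown sits.

Going by these compounds, whether the same change would shift the value of compound 1 or compound 2 stays open, since neither has a carboxy partner here. Also open, on these data alone, is what an amide or a primary alcohol would do in place of the carboxy group in compound 4.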